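Ortho substituent swap on the aroyl ring, chloro to methyl

This account rests on a few compounds, and the source may have more. Where it says the series, first, only, none or still open, it means among the compounds named here.

Within the data shown here, compound 1 `COc1cc2ncnc(NNC(=S)NC(=O)c3ccccc3Cl)c2cc1OC` is the weakest of the three measured members in a functional assay on MCF7 cells (Homo sapiens) for cytotoxicity, read by MTT assay, with a stated time of 72 h (on this read-out lower numbers stand for stronger inhibition and higher numbers for weaker inhibition), where compound 1 gives 23100 nM. The two unsubstituted-core analogues sit well below it: compound 2 `O=C(NC(=S)NNc1ncnc2ccccc12)c1ccc(F)cc1` gives 4590 nM and compound 3 `O=C(NC(=S)NNc1ncnc2ccccc12)c1cccc(Cl)c1` gives 3540 nM. Both gaps from compound 1 lie beyond the scatter; compound 1 also carries the two methoxy groups on the shared core, so the aroyl change and the core change are confounded in that comparison.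

Compound 4 `COc1cc2ncnc(NNC(=S)NC(=O)c3ccccc3C)c2cc1OC` differs from compound 1 by methyl in place of chloro on an aromatic carbon, set on an aromatic carbon of a six-membered aromatic ring of carbon only, ortho to a large group. Among the measured compounds shown here, the only measured step that touches the same aroyl ring is a 1.3-fold lower number from compound 2 to compound 3 (0.11 log units; within the scatter), a change of halogen and position that moved this assay only within the scatter. For the measured compounds named here, no measured pair changes a substituent ortho to a large group, and none swaps chloro for methyl, so the step is taken as small.

For compound 4 the expected step is a 1.1-fold lower number from compound 1 to compound 4 (0.04 log units; within the scatter), that is, no shift beyond the scatter. Compound 4 is therefore estimated at 21000 nM, with a range of 8000 nM to 55000 nM.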

Compound 4, half-maximal inhibitory concentration: 19300 nM
Compound 4: middle estimate off by 1.1-fold (0.04 log units), on the high side, and the stated range covers the measured number.
By their numbers in this assay, from the lowest: compounds 3 and 2 (each within the scatter of the next); then compounds 4 and 1 (each within the scatter of the next).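

Read in this assay the swap of 2-chlorophenyl to 2-methylphenyl gives a 1.2-fold lower number from compound 1 to compound 4 (0.08 log units; within the scatter) and this is the first measured step at a place ortho to a large group, so at this place on the aroyl ring the change of chloro to methyl leaves the number within the scatter. Both members of this pair carry the two methoxy groups on the shared core, which makes it a single-place comparison, unlike the comparison of compound 1 with compound 2 or compound 3. Nothing on hand accounts for the number holding across this swap.

As far as these compounds go, whether an amine, a carboxylic acid or a longer chain at this same place would move the number beyond the scatter stays open, as the two groups compared here give no sign of how far the place can be changed. Also open, from the compounds shown here alone, is how much of the gap between the methoxy-bearing compounds and compounds 2 and 3 belongs to the core and how much to the aroyl ring, as the core change and the aroyl change still travel together in every such comparison.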